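From Phenyl to 4-Fluorophenyl at the Limit of the Assay

The source may hold more compounds than are shown below. What is called first, only, known or untested is meant among the compounds shown, and "the series" means these compounds.

In a functional assay on HeLa cells (Homo sapiens) for antiproliferative activity, read by MTT assay, with a stated time of 72 h (on this read-out lower numbers stand for stronger inhibition and higher numbers for weaker inhibition), compound 2 `COc1cc(-n2ncnc2-c2ccccc2)cc(OC)c1OC` gives > 10000 nM as a limit, not a number. Compound 1 `COc1cc(-n2ncnc2-c2ccc(OC(F)(F)F)cc2)cc(OC)c1OC` gives > 10000 nM as a limit too. For the measured compounds named here, the only measured step that bears on the next change is a step that the two limits leave unreadable from compound 1 to compound 2 and it offers no size to build on. The evidence so far is the limit of > 10000 nM in this assay, at which 2 of the 2 values shown sit, and nothing more. Compound 3 `COc1cc(-n2ncnc2-c2ccc(F)cc2)cc(OC)c1OC` carries fluoro in place of hydrogen on an aromatic carbon, with fluoro in place of hydrogen on an aromatic carbon as its difference from compound 2. No change beyond the scatter is expected in this assay so the expected step is a step that the limit leaves unreadable from compound 2 to compound 3 without a firm direction. Compound 3 is estimated at 12000 nM within a range of 4000 nM to 30000 nM and may well return only a limit.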

Compound 3, half-maximal inhibitory concentration: > 10000 nM
Compound 3 was reported as a limit (the forecaster's own chance of this, stated with the estimate: 80%); the middle value does not contradict the limit.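

Compound 1, compound 2 and compound 3 each return only a limit, not a number, so no step among them can be read: the limit of > 10000 nM in this assay, at which 3 of the 3 values shown sit.

The compounds shown leave open whether hydrogen, fluoro and trifluoromethoxy differ at all in this assay.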